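From propyl to octyl in a short series

The compounds below may be only part of what the source reports. "The series", "measured", "known", "first", "only" and "open" are said of these compounds alone.

Compound 1 `CCCCCCCCOP(=O)(O)OCCSC(=S)N1CCCC1`: 53000 nM
Compound 2 `CCCCCCCCCCOP(=O)(O)OCCSC(=S)N1CCCCCC1`: 43300 nM
Compound 3 `CCCOP(=O)(O)OCCSC(=S)N1CCCCC1`: > 100000 nM

In a functional assay on MCF7 cells (Homo sapiens) for inhibition, read by MTT assay, with stated times of 18 h and 4 h (a lower number here means a stronger inhibitor, a higher number a weaker inhibitor), compound 3 gives > 100000 nM, which is a limit of the assay and not a number.

Compound 4 `CCCCCCCCOP(=O)(O)OCCSC(=S)N1CCCCC1` has not yet been measured. It keeps the core of compound 3 and differs from it by pentyl in place of hydrogen on a saturated chain carbon, three bonds along the chain from an oxygen on an unsaturated carbon. Cut one bond further out, the same difference reads propyl to octyl.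

The closest guide is compound 1, which carries the same octyl chain and gives 53000 nM in this assay. Compound 2 gives 43300 nM in this assay. Both of these values are numbers rather than limits. Compound 4 is therefore expected to come down from the limit into the measurable range, a move towards stronger inhibition. Compound 4 is expected to settle close to compound 1 at 53000 nM. The expected change is an at least 2.0-fold lower number from compound 3 to compound 4 (0.30 log units; that floor lies within the scatter). For compound 4 the estimated value is 50000 nM, with an expected range of 25000 nM to 95000 nM.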

Compound 4, half-maximal inhibitory concentration: 26000 nM
Beside the measured number, compound 4's estimate is 1.9-fold (0.28 log units) above it; the range from low to high includes it.
By their numbers in this assay, from the lowest: compounds 4, 2 and 1 (each within the scatter of the next, the first and the last beyond it). At a limit, above all of these: compound 3.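

In this assay, pentyl in place of hydrogen on a saturated chain carbon, three bonds along the chain from an oxygen on an unsaturated carbon, gives an at least 3.8-fold lower number from compound 3 to compound 4 (0.58 log units; beyond the scatter), which brings the core of compound 3 into the measurable range. The value of compound 3 is a limit of the assay and not a number, so the size of this step is only a floor: the limit of > 100000 nM in this assay, at which 1 of the 4 values shown sits. With the octyl chain held fixed, piperidin-1-yl in place of pyrrolidin-1-yl on a thiocarbonyl carbon gives a 2.0-fold lower number from compound 1 to compound 4 (0.31 log units; beyond the scatter), showing that the change at this second place also moves the number.

The compounds shown leave open how the number moves for chains lying between propyl and octyl, such as butyl or hexyl, and for a longer chain such as dodecyl on the core of compound 4. Also open, on these data alone, is what an amine or a carboxylic acid at the end of the octyl chain would do.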